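The compounds below may be only part of what the source reports. "The series", "measured", "known", "first", "only" and "open" are said of these compounds alone.

Compound 3 `Nc1ccccc1NC(=O)c1ccc(CSC(=S)N2CCN(c3cnccn3)CC2)cc1` stands at the top of the three compounds measured in a functional assay on MGC-803 cells (Homo sapiens) for antiproliferative activity, read by CCK-8 assay, with a stated time of 72 h, tested at 8 uM; a lower number here means a weaker effect, a higher number a stronger effect of the compound at the concentration tested: compound 3 gives 80.5%. Compound 1 `Nc1ccccc1NC(=O)c1ccc(CSC(=S)N2CCN(Cc3ccccn3)CC2)cc1` sits closer, as in this assay compound 1 gives 65.2%, while compound 2 `Nc1ccccc1NC(=O)c1ccc(CSC(=S)N2CCN(c3ccc(Cl)cc3)CC2)cc1` lies furthest away, since compound 2 gives 17.2%. The next compound, compound 4 `Nc1ccccc1NC(=O)c1ccc(CSC(=S)N2CCN(Cc3ccccc3)CC2)cc1`, differs from compound 3 in one place: benzyl in place of pyrazin-2-yl on an amine nitrogen in a ring. Among the measured compounds shown here, two measured steps bear on this change. Going to the aromatic hetero ring on the ring nitrogen gave a number 15.3 percentage points higher from compound 1 to compound 3 (beyond the scatter), and replacing an all-carbon aromatic ring directly on that nitrogen by the same hetero ring gave a number 63.3 percentage points higher from compound 2 to compound 3 (beyond the scatter). Both point the same way: the carbon-only groups on this nitrogen sit below the pyrazin-2-yl compound. Since compound 4 carries a benzyl group, which is closest in shape to the group of compound 1 that gave 65.2%, a downward step is expected, of the order of a number 30.5 percentage points lower from compound 3 to compound 4 (beyond the scatter). Compound 4 is therefore estimated at 50%, within a range from 20% to 75%.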

Compound 4, a percentage reported as inhibition, at one concentration (the size of the read-out at that concentration, not a potency): 19.7%
Estimate against measurement, compound 4: 30.3 percentage points above; measured number below the stated range.
By their numbers in this assay, from the lowest: compounds 2 and 4 (each within the scatter of the next); then compound 1; then compound 3.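

In this assay, phenyl in place of pyridin-2-yl on the saturated chain carbon gave a number 45.5 percentage points lower from compound 1 to compound 4 (beyond the scatter) and so separates two compounds that keep that chain carbon on the ring nitrogen. Benzyl in place of pyrazin-2-yl gave a number 60.8 percentage points lower from compound 3 to compound 4 (beyond the scatter) while benzyl in place of 4-chlorophenyl gave a number 2.5 percentage points higher from compound 2 to compound 4 (within the scatter) and so, across these four compounds, those with ring nitrogen atoms in the aromatic group lie apart from those whose aromatic ring is of carbon only, with no compound against this pattern. Nothing measured here gives a reason for this split.

The compounds shown leave open how a pyrimidin-2-yl group on the ring nitrogen would compare with pyrazin-2-yl. They also leave open whether an amine on the benzyl ring would change its number.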